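From methoxy to methylsulfanyl in compound 3

The source may report more compounds than this note shows. Statements on the series, on what has been measured and on what is new or still open speak of the compounds shown alone.

In an ADME assay on HT-29 cells (Homo sapiens) for cytotoxicity, read by MTT assay, with a stated time of 72 h (on this read-out lower numbers stand for stronger inhibition and higher numbers for weaker inhibition), compound 1 (`COc1ccc(C2=C(c3cc(OC)c(OC)c(OC)c3)C(=O)C(O)C2)cc1`) gives < 1 ug/mL, which is a limit of the assay and not a number. For the measured compounds named here, compound 2 (`COc1ccc(C2=C(c3cc(OC)c(OC)c(OC)c3)C(=O)C(O[SiH2]C(C)(C)C)C2)cc1`) gives 5 ug/mL, the only actual number so far. Going by the values given here, the one measured step is an at least 5.0-fold higher number from compound 1 to compound 2 (0.69 log units; beyond the scatter). It concerns the oxygen on a saturated carbon, and compound 3 (`COc1cc(C2=C(c3ccc(SC)cc3)CC(O[SiH2]C(C)(C)C)C2=O)cc(OC)c1OC`) keeps the group found there in compound 2. Compound 3 differs instead by methylsulfanyl in place of methoxy on an aromatic carbon, with methylsulfanyl in place of methoxy on an aromatic carbon, para to a large group. Among the compounds with values here, no measured step covers this place, so its size cannot be carried over, and no step beyond the scatter is expected in this assay. The expectation therefore rests on compound 2 at 5 ug/mL. The estimate is no change at the digits printed from compound 2 to compound 3 (within the scatter). For compound 3 the expected value is 5 ug/mL, with an estimated range of 2 ug/mL to 12 ug/mL.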

Compound 3, half-maximal inhibitory concentration: < 1 ug/mL
Compound 3 was reported as a limit (the forecaster's own chance of this, stated with the estimate: 10%); at least 5.0-fold (0.69 log units) between middle value and limit.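

The earlier step concerned only the oxygen on a saturated carbon; this one shows that the aromatic carbon para to a large group also matters in this assay, with methylsulfanyl in place of methoxy giving an at least 5.0-fold lower number from compound 2 to compound 3 (0.69 log units; beyond the scatter). The group on that oxygen is the same in both compounds, so it does not alone fix the number seen for compound 2. Compound 3 gives < 1 ug/mL, which is a limit of the assay and not a number, and the full size of the step stays unread because of where the values stop: the limit of < 1 ug/mL in this assay, at which 2 of the 3 values shown sit.

What the compounds shown leave open is whether a longer chain on the sulfur, such as ethylsulfanyl, or an amine at this place would give a similar step. As far as these compounds go, whether methylsulfanyl would have any effect alongside the free hydroxyl of compound 1 also remains open.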